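Replacing the thiophene of compound 1 with a hydroxyethyl chain

The compounds below may be only part of what the source reports. "The series", "measured", "known", "first", "only" and "open" are said of these compounds alone.

Compound 1 `c1ccc(-n2cc3cnc(-c4ccsc4)cc3n2)cc1` is the reference point of this small set. In a functional assay on MCF7 cells (Homo sapiens) for inhibition, read by fluorescence, with a stated time of 72 h (on this read-out higher numbers stand for weaker inhibition of growth and lower numbers for stronger inhibition of growth), compound 1 gives 9800 nM, the lowest of the two numbers recorded; its nearest neighbour, compound 2 `Cc1nc(-c2ccsc2)cc2nn(-c3ccccc3)cc12`, gives 22200 nM. Within the data shown here, the only single-point step measured so far is a 2.3-fold higher number from compound 1 to compound 2 (0.36 log units; beyond the scatter), a methyl in place of hydrogen on an aromatic carbon. Compound 3 `Cn1cc2cnc(-c3ccccc3)cc2n1` returns only a limit of the assay, > 100000 nM, as stated in the limit of > 100000 nM in this assay, at which 1 of the 3 values shown sits.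

Compound 4 `OCCc1cc2nn(-c3ccccc3)cc2cn1` is not yet measured. It differs from compound 1 by 2-hydroxyethyl in place of thiophen-3-yl on an aromatic carbon. Among the measured compounds shown here, no measured step touches this position or this kind of exchange, so the methyl step from compound 1 to compound 2 gives no direct guide; it shows only that a small change on the core can move the number modestly. With the five-atom aromatic ring removed in favour of a short polar chain, a weakening beyond the scatter is expected, and compound 4 is estimated at 40000 nM (range 12000 nM to 150000 nM), corresponding to an expected step of a 4.1-fold higher number from compound 1 to compound 4 (0.61 log units; beyond the scatter).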

Compound 4, concentration for 50% growth inhibition: > 100000 nM
Compound 4 gave a limit, no number; the forecaster's own chance of this, stated with the estimate: 35%; middle value at least 2.5-fold (0.39 log units) away from the limit.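

In this assay compound 4 gives > 100000 nM, a limit of the assay and not a number. Exchanging thiophen-3-yl for 2-hydroxyethyl on the aromatic carbon next to the ring nitrogen gives an at least 10-fold higher number from compound 1 to compound 4 (1.00 log units; beyond the scatter), which sets a minimum for the step and not its size, so this position is now shown to matter far more than the earlier compounds could indicate. The read-out offers no further resolution for this change, and compound 4 joins the values held at the ceiling: the limit of > 100000 nM in this assay, at which 2 of the 4 values shown sit.

This single change removes the five-membered aromatic ring and brings in a hydrogen-bond donor together, and the compounds shown do not separate the two. On these data alone, how a plain ethyl chain or a 2-aminoethyl chain would read at this position remains open.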